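The compounds below may be only part of what the source reports. "The series", "measured", "known", "first", "only" and "open" are said of these compounds alone.

In a functional assay on KB cells (Homo sapiens) for antiproliferative activity, read by MTT assay, with a stated time of 72 h (a lower number here means a stronger inhibitor, a higher number a weaker inhibitor), compound 2 `O=C(Nc1cccc(I)c1)C(Cl)Cl` gives 5250 nM, while compound 3 `N#Cc1cccc(NC(=O)C(Cl)Cl)c1` gives 60900 nM, the highest of the two numbers recorded. Compound 1 `Cc1cccc(NC(=O)C(Cl)Cl)c1` stands with "not determined" (no result reported) in this assay, so it adds nothing to the comparison. The single measured step among these compounds is a 12-fold higher number from compound 2 to compound 3 (1.06 log units; beyond the scatter), a large move towards weaker inhibition.

Compound 4 `O=C(Nc1cccc(C(F)(F)F)c1)C(Cl)Cl` differs from compound 3 in one place: trifluoromethyl in place of cyano on an aromatic carbon. Among the compounds with values here, no measured step covers this particular exchange. Within the data shown here, the only step that touches the same aromatic carbon is the one from iodo to cyano, and it is the sole guide available. Because a 12-fold higher number from compound 2 to compound 3 (1.06 log units; beyond the scatter) raised the number sharply when cyano arrived, taking cyano away again is expected to undo some of that rise, although nothing measured shows how much, and trifluoromethyl has not been tested on this core at all. The step from compound 3 to compound 4 is therefore expected to be a 6.1-fold lower number from compound 3 to compound 4 (0.78 log units; beyond the scatter), a move to a lower number, with considerable uncertainty on both sides. Compound 4 is estimated at 10000 nM, within a range from 2000 nM to 50000 nM.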

Compound 4, half-maximal inhibitory concentration: 8860 nM
The estimate for compound 4 lay 1.1-fold (0.05 log units) above the measured number, within the range that was stated.
By their numbers in this assay, from the lowest: compounds 2 and 4 (each within the scatter of the next); then compound 3.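

In this assay there is a 6.9-fold lower number from compound 3 to compound 4 (0.84 log units; beyond the scatter) when trifluoromethyl replaces the nitrile, and a 1.7-fold higher number from compound 2 to compound 4 (0.23 log units; within the scatter) when it replaces iodo, so trifluoromethyl and iodo cannot be told apart at this aromatic carbon. The earlier single step from iodo to cyano could not show which of its two compounds was the unusual one, but a third group now sides with iodo, leaving compound 3, with its nitrile, as the one that stands apart among these three. Nothing measured on these compounds explains why the nitrile gives the weaker number.

The compounds shown leave open whether the high number is peculiar to the nitrile or would also appear with other groups on this carbon, such as an amine, a carboxylic acid or a methoxy group. They also leave open whether the same differences between these three groups would hold if another part of the shared core were changed.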